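The compounds below may be only part of what the source reports. "The series", "measured", "known", "first", "only" and "open" are said of these compounds alone.

Notes on the series. In a functional assay on SMMC-7721 cells (Homo sapiens) for antiproliferative activity, read by MTT assay, with a stated time of 48 h (a higher number here means a weaker inhibitor, a lower number a stronger inhibitor), compound 2 `COC/C1=C/C[C@](C)(CCC=C(C)C)/C=C/[C@@H](OC(=O)C=C(C)C)[C@](C)(O)/C=C/C1=O` gives 11000 nM, the second highest of the three numbers in hand. Compound 1 `CC(=O)OC/C1=C/C[C@](C)(CCC=C(C)C)/C=C/[C@@H](OC(=O)C=C(C)C)[C@](C)(OC(C)=O)/C=C/C1=O` sits on the stronger side with 4130 nM, a gap beyond the scatter; compound 3 `CC(C)=CCC[C@]1(C)/C=C/[C@@H](OC(=O)C=C(C)C)[C@](C)(O)/C=C/C(=O)/C(C[Si](c2ccccc2)(c2ccccc2)C(C)(C)C)=C\C1` sits on the weaker side with 38000 nM, also beyond the scatter. No single-change pair among these three is available. Compound 4 `CC(C)=CCC[C@]1(C)/C=C/[C@@H](OC(=O)C=C(C)C)[C@](C)(O)/C=C/C(=O)/C(COC(=O)c2ccc([N+](=O)[O-])cc2)=C\C1` differs from compound 2 by (4-nitrophenyl)carbonyl in place of methyl on an oxygen on a saturated carbon. An ester at this oxygen is shared with compound 1, whose value is lower than that of compound 2, so a modest step toward a lower number is expected for compound 4, a 1.4-fold lower number from compound 2 to compound 4 (0.14 log units; within the scatter), though it may not exceed the scatter. Compound 4 is estimated at 8000 nM, within 3000 nM to 25000 nM.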

Compound 4, half-maximal inhibitory concentration: 2560 nM
Beside the measured number, compound 4's estimate is 3.1-fold (0.49 log units) above it; the measured number lies below the stated range.
By their numbers in this assay, from the lowest: compounds 4 and 1 (each within the scatter of the next); then compound 2; then compound 3.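

For the compounds shown here, at the oxygen on a saturated carbon, (4-nitrophenyl)carbonyl in place of methyl gives a 4.3-fold lower number from compound 2 to compound 4 (0.63 log units; beyond the scatter) in this assay and so provides the first single-change reading at this position. The step is beyond the scatter, and it shows that a larger entering group carrying an aromatic ring goes with a lower number here, not a higher one. Nothing in hand bears on why the number falls.

Going by these compounds, whether the step follows from the ester link itself or from the 4-nitrophenyl ring stays open; an unsubstituted benzoyl or a 4-aminobenzoyl group at this oxygen would separate the two.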